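A few compounds are considered here, and "the series" means these few. Any claim that something is new, unique, unknown or untested is made for them only; others in the source may bear on it.

In a functional assay on the whole organism (strain Wistar) for inhibition, with Rattus norvegicus as the target, read by paw edema, with stated times of 60 min and 6 h, at a dose of 100 mg/kg by the oral route (a lower number here means less inhibition, a higher number more inhibition at the dose given (going by the name of the read-out)), compound 3 `CCCNC(=O)CC1CCc2cc(OC)c(OC)cc21` gives 22.2%, the second highest of the three numbers measured. Compound 1 `COc1cc2c(cc1OC)C(CC(=O)O)CC2` gives 20.4% in the same assay, and compound 2 `COc1cc2c(cc1OC)C(CC(=O)N(C)C)CC2` gives 33.3%. a number 1.8 percentage points higher from compound 1 to compound 3 (within the scatter), while a number 11.1 percentage points lower from compound 2 to compound 3 (beyond the scatter). Compound 4 `CCCCNC(=O)CC1CCc2cc(OC)c(OC)cc21` differs from compound 3 by methyl in place of hydrogen on a saturated chain carbon, three bonds along the chain from an amide-type nitrogen. Among the measured compounds shown here, both measured steps change the group on the carbonyl carbon; no measured step lengthens the chain on the amide-type nitrogen, so neither bears directly on this change. With nothing in the series pointing to a shift in either direction, compound 4 is expected to sit within the scatter of compound 3, a number 0.2 percentage points lower from compound 3 to compound 4 (within the scatter). The estimate for compound 4 in this assay is 22%, with a range from 10% to 34%.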

Compound 4, a percentage reported as inhibition, in the whole organism at one dose (the size of the read-out at that dose, not a potency): 24.1%
Compound 4: middle estimate off by 2.1 percentage points, on the low side; measured number inside the range.
By their numbers in this assay, from the lowest: compounds 1, 3, 4 and 2 (each within the scatter of the next, the first and the last beyond it).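

In this assay, among the compounds shown here, propyl to butyl is the first measured chain step at this position, and a number 1.9 percentage points higher from compound 3 to compound 4 (within the scatter) shows that this added methyl leaves the read-out level. With butylamino on the carbonyl carbon, a number 9.2 percentage points lower from compound 2 to compound 4 (within the scatter) and a number 3.7 percentage points higher from compound 1 to compound 4 (within the scatter) are both printed within the scatter, whereas the propylamino compound 3 stood clear of compound 2. No measurement here offers a reason for these numbers.

On these data alone, whether a longer chain on the amide-type nitrogen would keep the read-out level stays open. So does the effect of an amine or a hydroxy group on that chain.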